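Changing one group on compound 1

The source may hold more compounds than are shown below. What is called first, only, known or untested is meant among the compounds shown, and "the series" means these compounds.

Values so far in a functional assay on RS4-11 cells (Homo sapiens) for inhibition, read by CCK-8 assay, with a stated time of 48 h (on this read-out higher numbers stand for weaker inhibition and lower numbers for stronger inhibition), for three compounds
- compound 1 `O=C(Nc1ccc(F)cc1)N1CCN(S(=O)(=O)c2sccc2-c2ccccc2Oc2ccc(O)c(O)c2)CC1` gives 6800 nM here
- compound 2 `COc1ccc(Oc2ccccc2-c2ccsc2S(=O)(=O)N2CCN(C(=O)Nc3ccc(F)cc3)CC2)cc1OC` gives 14900 nM here
- compound 3 `O=[N+]([O-])c1ccc(Oc2ccccc2-c2ccc(S(=O)(=O)NCCNC(=S)Nc3cccc(Cl)c3)s2)cc1` gives > 50000 nM as a limit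

Of the two real numbers, compound 1 has the lower, which makes it the stronger of that pair. Compound 3 stands at the limit of > 50000 nM in this assay, at which 1 of the 3 values shown sits, and that is a limit, not a number.

The next compound to be tested is compound 4 (`O=[N+]([O-])c1ccc(NC(=S)N2CCN(S(=O)(=O)c3sccc3-c3ccccc3Oc3ccc(O)c(O)c3)CC2)cc1`). It keeps the 3,4-dihydroxyphenyl of compound 1 and exchanges one group on an amine nitrogen in a ring (a group of 12 heavy atoms (7 carbon, 2 nitrogen, 2 oxygen, 1 sulfur; one six-membered aromatic ring of carbon only) in place of a group of 10 heavy atoms (7 carbon, 1 nitrogen, 1 oxygen, 1 fluorine; one six-membered aromatic ring of carbon only), on an amine nitrogen in a ring). Going by the values given here, no measured step touches that place. Among the compounds with values here, the one measured step is modest (a 2.2-fold higher number from compound 1 to compound 2 (0.34 log units; beyond the scatter)) and concerns something else: 3,4-dimethoxyphenyl in place of 3,4-dihydroxyphenyl. Within the data shown here, compound 3 differs from compound 1 in more than one place, so it offers no single step to compare.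

Among the measured compounds shown here, that leaves the modest step to compound 2 as the only guide to size in this assay, and it gives no direction for the new change. The expected change is small and has no clear direction (a 1.0-fold higher number from compound 1 to compound 4 (0.01 log units; within the scatter)). For compound 4 the estimate is 7000 nM (expected range 2000 nM to 25000 nM).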

Compound 4, half-maximal inhibitory concentration: 9000 nM
For compound 4 the middle estimate is 1.3-fold (0.11 log units) below the measured one; the measured number falls inside the stated range.
By their numbers in this assay, from the lowest: compounds 1, 4 and 2 (each within the scatter of the next, the first and the last beyond it). At a limit, above all of these: compound 3.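

In this assay, going by these compounds alone, exchanging the group on the amine nitrogen in the ring gives a 1.3-fold higher number from compound 1 to compound 4 (0.12 log units; within the scatter), so this is the first sign that the position accepts a substantial change without a difference that can be told from the scatter. The exchange is not a small one: (4-fluorophenyl)carbamoyl leaves, and the entering group has more heavy atoms, brings in sulfur, loses the fluorine and adds hydrogen-bond acceptors, yet the aromatic ring and the single hydrogen-bond donor remain, and these several differences together leave the two compounds indistinguishable here, although one step cannot show what each difference does alone. Nothing measured here explains this outcome.

From the compounds shown here alone, it remains open whether a much smaller group on that nitrogen, such as a methyl or an acetyl, or a group holding a carboxylic acid or an amine, would leave the value just as unchanged. Also open, going by these compounds, is whether 3,4-dimethoxyphenyl in place of 3,4-dihydroxyphenyl would have the same effect alongside the entering group of compound 4 as it does in a 2.2-fold higher number from compound 1 to compound 2 (0.34 log units; beyond the scatter).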